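This account rests on a few compounds, and the source may have more. Where it says the series, first, only, none or still open, it means among the compounds named here.

In an ADME assay on LLC-MK2 cells (Macaca mulatta) for cytotoxicity, read by spectrophotometry and crystal violet staining, with a stated time of 4 days (on this read-out higher numbers stand for lower toxicity in this test and lower numbers for higher toxicity in this test), the compounds measured so far stand as follows:

Compound 1 `CC(C)n1ncc2c(C(=O)Nc3ncccn3)cc(-c3ccsc3)nc21`: 50000 nM
Compound 2 `CNS(=O)(=O)c1cccc(NC(=O)c2cc(-c3cccs3)nc3c2cnn3C(C)C)c1`: 25000 nM
Compound 3 `CC(C)n1ncc2c(C(=O)N3CCc4cccnc43)cc(-c3cccs3)nc21`: 50000 nM

Compound 3 sits level with compound 1 at the digits shown, the two together giving the highest numbers of the three, and the value of compound 2 differs from that of compound 3 only within the usual scatter. All three therefore sit in one band of low toxicity in this test.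

Compound 4 `CC(C)n1ncc2c(C(=O)Nc3ccccn3)cc(-c3cccs3)nc21` differs from compound 3 in one place: a group of 7 heavy atoms (5 carbon, 2 nitrogen; one six-membered aromatic ring with 1 hetero atom) in place of a group of 9 heavy atoms (7 carbon, 2 nitrogen; one five-membered non-aromatic ring with 1 hetero atom, one six-membered aromatic ring with 1 hetero atom), on a carbonyl carbon

Within the data shown here, no step between measured compounds is available to calibrate this change, so the expectation rests on the band itself. Because compound 1 gives 50000 nM and compound 3 gives 50000 nM with no movement between them, the step of a 1.1-fold lower number from compound 3 to compound 4 (0.05 log units; within the scatter) is expected to be none beyond the scatter. Compound 4 is estimated at 45000 nM, with a range from 20000 nM to 100000 nM.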

Compound 4, half-maximal cytotoxic concentration: > 200000 nM
Compound 4 gave a limit, no number; the forecaster's own chance of this, stated with the estimate: 30%; at least 4.4-fold (0.64 log units) between middle value and limit.
By their numbers in this assay, from the lowest: compounds 2, 1 and 3 (each within the scatter of the next). At a limit, above all of these: compound 4.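

In this assay, replacing the group of 9 heavy atoms on the carbonyl carbon with (pyridin-2-yl)amino, which adds a hydrogen-bond donor, gives an at least 4.0-fold higher number from compound 3 to compound 4 (0.60 log units; beyond the scatter). Among these compounds, this shows that a change at this place can shift the read-out beyond the scatter, towards lower toxicity in this test, which the earlier compounds did not show. Compound 4 stands at a limit and not at a number, so the full size of the step is unknown: the limit of > 200000 nM in this assay, at which 1 of the 4 values shown sits.

A single step cannot separate the added donor from the loss of the five-membered ring. As far as these compounds go, whether a plain amine such as dimethylamino, or a carboxylic acid, on this carbonyl carbon would behave likewise remains open.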